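Fluoro for Methyl on the Pendant Phenyl Ring

A few compounds are considered here, and "the series" means these few. Any claim that something is new, unique, unknown or untested is made for them only; others in the source may bear on it.

Compound 1, `COc1cc2c(Oc3ccc(NC(=O)c4cc(-c5ccccc5C)ccn4)cc3F)ccnc2cc1OCCCN1CCN(C)CC1`, and compound 2, `COc1cc2c(Oc3ccc(NC(=O)c4cc(-c5ccccc5F)ccn4)cc3F)ccnc2cc1OCCCN1CCN(C)CC1`, share one core and differ only in fluoro in place of methyl on an aromatic carbon. In a functional assay on NCI-H460 cells (Homo sapiens) for cytotoxicity, read by MTT assay, with a stated time of 72 h (on this read-out lower numbers stand for stronger inhibition and higher numbers for weaker inhibition), compound 1 gives 150 nM, and compound 2 gives 140 nM; this is a 1.1-fold lower number from compound 1 to compound 2 (0.03 log units; within the scatter). Compound 3, `COc1cc2c(Oc3ccc(NC(=O)c4nccc(-c5ccc(C)cc5)n4)cc3F)ccnc2cc1OCCCN1CCCC1`, rests on a different core, and the difference between the two cores is not broken down here. In this assay compound 3 gives 440 nM. Compound 4, `COc1cc2c(Oc3ccc(NC(=O)c4nccc(-c5ccc(F)cc5)n4)cc3F)ccnc2cc1OCCCN1CCCC1`, is not yet measured and differs from compound 3 by fluoro in place of methyl on an aromatic carbon. This is the same kind of change as from compound 1 to compound 2, but there the fluoro stood ortho to a large group, here it stands para to a large group. Because the earlier step was a 1.1-fold lower number from compound 1 to compound 2 (0.03 log units; within the scatter), the step of a 1.1-fold lower number from compound 3 to compound 4 (0.04 log units; within the scatter) is expected to be small as well. The number expected for compound 4 in this assay is 400 nM, between 200 nM and 900 nM.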

Compound 4, half-maximal inhibitory concentration: 300 nM
Compound 4: the middle estimate sits 1.3-fold (0.12 log units) above what was measured, within the range that was stated.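

In this assay, fluoro in place of methyl gives a 1.5-fold lower number from compound 3 to compound 4 (0.17 log units; within the scatter), so on this core, too, the swap produces no step beyond the usual scatter. The two cores agree on this change: the same change on two cores in this assay, a 1.1-fold lower number (0.03 log units; within the scatter) from compound 1 to compound 2 and a 1.5-fold lower number (0.17 log units; within the scatter) from compound 3 to compound 4, 1.4-fold (0.14 log units) apart, within the scatter of two such steps. For the compounds shown here, this is only one pair of compounds on each of two cores, with the fluoro at a different place on the phenyl ring in each pair, so it shows that the result carried over here, not that it would hold on every core.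

The compounds shown leave open what a group other than methyl or fluoro would do at these places. Chloro, methoxy, trifluoromethyl, an amine or a carboxylic acid could each give a larger step.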